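Fluoro to methyl swap on the phenoxy group

This account rests on a few compounds, and the source may have more. Where it says the series, first, only, none or still open, it means among the compounds named here.

Measured in a functional assay on HepG2 cells (Homo sapiens) for antiproliferative activity, read by MTT assay, with a stated time of 72 h; on this read-out lower numbers stand for stronger inhibition and higher numbers for weaker inhibition:
compound 1 `Cc1nn(C)c(Oc2ccc(F)cc2)c1/C=N\CCCCCOc1cc2oc(=O)cc(C)c2cc1Cl` gives > 25000 nM, a limit of the assay rather than a number.
compound 2 `Cc1nn(C)c(Oc2ccc(Br)cc2)c1/C=N\CCCCCOc1cc2oc(=O)cc(C)c2cc1Cl` gives 13800 nM.

Compound 1 stands at the limit (the limit of > 25000 nM in this assay, at which 1 of the 2 values shown sits), so only a bound on its number is known. Bromo for fluoro brought an at least 1.8-fold lower number from compound 1 to compound 2 (0.25 log units; that floor lies within the scatter). Compound 3 `Cc1ccc(Oc2c(/C=N\CCCCCOc3cc4oc(=O)cc(C)c4cc3Cl)c(C)nn2C)cc1` differs from compound 1 by methyl in place of fluoro on an aromatic carbon. For the measured compounds named here, no measured step covers methyl, and the one halogen swap stayed within the scatter. For compound 3 a number near the limit is therefore expected, with an at least 1.2-fold lower number from compound 1 to compound 3 (0.09 log units; that floor lies within the scatter) estimated as no step beyond the scatter. The expected value for compound 3 is 20000 nM, between 8000 nM and 60000 nM.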

Compound 3, half-maximal inhibitory concentration: 10300 nM
Estimate against measurement, compound 3: 1.9-fold (0.29 log units) above; the range from low to high includes it.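

In this assay, methyl in place of fluoro on the carbon para to a large group gives a step that clears the scatter: an at least 2.4-fold lower number from compound 1 to compound 3 (0.38 log units; beyond the scatter). Methyl and bromo at this place cannot be separated: a 1.3-fold lower number from compound 2 to compound 3 (0.13 log units; within the scatter). As far as these compounds go, compound 1 is known only as a limit of the assay, so the fluoro to methyl step is a floor and its full size remains unknown: the limit of > 25000 nM in this assay, at which 1 of the 3 values shown sits.

Open, from the compounds shown here alone, is how an amine, a methoxy group or a carboxylic acid would read at this place. Also open, going by these compounds, is whether any group here gives a number clearly lower than that of compound 3.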